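Adding Fluoro to a Urea Pair Tested on Rice

The source may hold more compounds than are shown below. What is called first, only, known or untested is meant among the compounds shown, and "the series" means these compounds.

Compound 1, `Cc1ccccc1NC(=O)N[C@@H](C)c1ccccc1`, gives 100% in an ADME assay on the whole organism with Oryza sativa as the target, tested at 0.1 uM; on this read-out higher numbers stand for a weaker effect at the one concentration tested and lower numbers for a stronger effect.
Compound 2, `C[C@H](NC(=O)Nc1ccccc1C(C)(C)C)c1ccccc1`, gives 101% in this assay.

These two compounds share a urea core and differ only in one group on an aromatic carbon, tert-butyl in place of methyl, and the measured step is a number 1 percentage points higher from compound 1 to compound 2 (within the scatter). Compound 1 therefore stands with compound 2 inside the usual scatter; the two numbers cannot be told apart.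

Compound 3, `Cc1cc(F)ccc1NC(=O)N[C@@H](C)c1ccccc1`, has not yet been measured. It differs from compound 1 by fluoro in place of hydrogen on an aromatic carbon, the fluoro entering meta to a methyl group and para to a large group on the same ring. Within the data shown here, the only measured step bears on this change in so far as it alters that ring, and it stayed within the scatter. No step beyond the scatter is therefore expected here, and the estimate is no change at the digits printed from compound 1 to compound 3 (within the scatter). Compound 3 is expected to give about 100% in this assay, within a range from 88% to 108%.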

Compound 3, a percentage reported as activity, at one concentration (the size of the read-out at that concentration, not a potency): 99%
For compound 3 the middle estimate is 1 percentage points above the measured one; the range from low to high includes it.
By their numbers in this assay, from the lowest: compounds 3, 1 and 2 (each within the scatter of the next).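

In this assay, fluoro in place of hydrogen on this aromatic carbon, meta to a methyl group and para to a large group, gives a number 1 percentage points lower from compound 1 to compound 3 (within the scatter), so the two compounds cannot be told apart. The earlier pair changed the group on a different carbon of this ring, whereas this step adds a single fluorine atom where only hydrogen stood, and it too stays inside the scatter. Nothing available explains why this read-out stays level across the change.

The compounds shown leave open whether an amine or a carboxylic acid on this same carbon would give a step beyond the scatter. Among these compounds, with every step so far inside the scatter, they also leave open whether any change on this ring can move the number in this assay.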